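Swapping Trifluoromethyl for Cyano on an Aromatic Ring

The source may hold more compounds than are shown below. What is called first, only, known or untested is meant among the compounds shown, and "the series" means these compounds.

Of the compounds shown here, three have been tested so far in an ADME assay (liver) for metabolic stability, with Liver microsome (Rattus norvegicus) as the target, read by LC-MS, using microsomes, with a stated time of 30 min, tested at 4 uM (a higher number here means that more of the compound is left, a lower number that less of the compound is left), and their numbers lie close together. Compound 1 (`CCN1CCN(c2nc(C)nc3c2nc(-c2ccccc2Cl)n3C)CC1`) gives 30% here and compound 2 (`Cc1nc(N2CCN(C)CC2)c2nc(-c3ccccc3Cl)n(CCN3CCCC3=O)c2n1`) gives 28% in the same test. Compound 3 (`Cc1nc(N2CCN(C)CC2)c2nc(-c3ccccc3C(F)(F)F)n(C3CCOCC3)c2n1`) gives 38% and stands within the usual scatter of both others, so the three cannot be told apart.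

Compound 4 (`Cc1nc(N2CCN(C)CC2)c2nc(-c3ccccc3C#N)n(C3CCOCC3)c2n1`) has not been measured yet. It matches compound 3 except for one group: cyano in place of trifluoromethyl on an aromatic carbon with cyano in place of trifluoromethyl on an aromatic carbon. Among the measured compounds shown here, no two measured compounds differ in just one place, so the data offer no direct precedent for this swap. The best starting point is therefore compound 3 at 38% with no shift beyond the scatter expected in this assay for this change. The estimated change is small, namely a number 2 percentage points lower from compound 3 to compound 4 (within the scatter) and no more than that. Compound 4 is expected at 36% (estimated range 22% to 50%).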

Compound 4, percent of the compound remaining: 21%
The estimate for compound 4 lay 15 percentage points above the measured number, and the stated range ends above it.
By their numbers in this assay, from the lowest: compounds 4, 2, 1 and 3 (each within the scatter of the next, the first and the last beyond it).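

Among the compounds shown here, this is the first pair in the set that differs in one place only, and in this assay putting cyano in place of trifluoromethyl on this aromatic carbon gives a number 17 percentage points lower from compound 3 to compound 4 (beyond the scatter) and so shows that the group held at this position can change how much compound is left. The three earlier compounds could not be told apart, so they gave no such sign. Nothing available bears on why this step occurs.

A single pair cannot show whether the same swap would give a similar step with a different group elsewhere on the shared core. From the compounds shown here alone, how other groups on this aromatic carbon would read, such as methoxy, an amine or a carboxylic acid, also stays open, as does whether a smaller or larger step would follow.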